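Compound 4: methoxy removal from compound 1

The source may hold more compounds than are shown below. What is called first, only, known or untested is meant among the compounds shown, and "the series" means these compounds.

Compound 1 `COc1ccc2oc(CSC(=S)N3CCOCC3)cc(=O)c2c1` is the reference point. In a functional assay on LM7 cells (Homo sapiens) for antiproliferative activity, read by MTT assay, with a stated time of 72 h (a lower number here means a stronger inhibitor, a higher number a weaker inhibitor), compound 1 gives 11000 nM, the lowest of the three numbers, although all three lie within the scatter of one another. Compound 2 `COc1ccc2oc(CSC(=S)N(C(C)C)C(C)C)cc(=O)c2c1` gives 19100 nM; the step of a 1.7-fold higher number from compound 1 to compound 2 (0.24 log units; within the scatter) puts diisopropylamino in place of morpholin-4-yl on the thiocarbonyl carbon. Compound 3 `CN1CCN(C(=S)SCc2coc3ccccc3c2=O)CC1` gives 17600 nM; it differs from compound 1 in two places, so the two values can only be set side by side.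

Compound 4 `O=c1cc(CSC(=S)N2CCOCC2)oc2ccccc12` is not yet measured. It differs from compound 1 by hydrogen in place of methoxy on an aromatic carbon. Going by the values given here, no measured single-point step covers this change: the one available step concerns only the amine on the thiocarbonyl carbon and is within the scatter. Compounds 1 and 3 show that a compound without the methoxy, carrying a different amine, lands close to compound 1. The step expected here is a 1.3-fold higher number from compound 1 to compound 4 (0.10 log units; within the scatter), nothing beyond the scatter. Compound 4 is expected to give 14000 nM in this assay, with a range from 6000 nM to 35000 nM.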

Compound 4, half-maximal inhibitory concentration: 25200 nM
For compound 4 the middle estimate is 1.8-fold (0.26 log units) below the measured one; measured number inside the range.
By their numbers in this assay, from the lowest: compounds 1, 3, 2 and 4 (each within the scatter of the next, the first and the last beyond it).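

Methoxy on this aromatic carbon, meta to a fused ring and para to a fused ring, is the first place in the series where a single change moves the number beyond the scatter in this assay: the step is a 2.3-fold higher number from compound 1 to compound 4 (0.36 log units; beyond the scatter) and is modest in size. Going by these compounds alone, the only other single change on record, on the amine side, stays within the scatter as a 1.7-fold higher number from compound 1 to compound 2 (0.24 log units; within the scatter), so the methoxy position is so far the only one with a readable effect, seen in one pair with morpholin-4-yl held fixed. Nothing measured on these compounds accounts for the step.

On these data alone, whether methoxy itself matters or any group larger than hydrogen would serve stays open, since neither hydroxy, fluoro nor ethoxy appears at this carbon. Also open, as far as these compounds go, is whether the same step holds with another amine on the thiocarbonyl carbon, such as piperidin-1-yl.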